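The source may report more compounds than this note shows. Statements on the series, on what has been measured and on what is new or still open speak of the compounds shown alone.

Measured compounds:
- compound 1 `CCCOc1ccc2oc(/C=C/[S+](C)[O-])cc(=O)c2c1`; in a functional assay on A549 cells (Homo sapiens) for cytotoxicity, with a stated time of 48 h (on this read-out lower numbers stand for stronger inhibition and higher numbers for weaker inhibition), compound 1 gives 1100 nM
- compound 2 `Cc1ccc2oc(/C=C/[S+](C)[O-])cc(=O)c2c1`; in this assay compound 2 gives 1700 nM
- compound 3 `CC(C)COc1ccc2oc(/C=C/[S+](C)[O-])cc(=O)c2c1`; in this assay compound 3 gives 1100 nM

Compound 2 stands at the highest of the three numbers in this assay, but neither of its steps to the other two goes beyond the scatter: a 1.5-fold higher number from compound 1 to compound 2 (0.19 log units; within the scatter) and a 1.5-fold lower number from compound 2 to compound 3 (0.19 log units; within the scatter). The third pair, no change at the digits printed from compound 1 to compound 3 (within the scatter), shows that two different alkoxy groups on the same aromatic carbon give the same number.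

The next compound is compound 4 `CC(C)Oc1ccc2oc(/C=C/[S+](C)[O-])cc(=O)c2c1`. Its change from compound 2: isopropoxy in place of methyl on an aromatic carbon. For the measured compounds named here, two measured steps bear on this exchange of methyl for an alkoxy group on that aromatic carbon. Going from alkoxy to methyl, a 1.5-fold higher number from compound 1 to compound 2 (0.19 log units; within the scatter); going from methyl to alkoxy, a 1.5-fold lower number from compound 2 to compound 3 (0.19 log units; within the scatter). Both are small and within the scatter, and both point the same way, toward a somewhat lower number for the alkoxy compound. Nothing in the three compounds separates one alkoxy group from another, so the size of the alkoxy group is not expected to matter here.

The expected step in this assay is therefore a small one toward a lower number, not beyond the scatter: a 1.4-fold lower number from compound 2 to compound 4 (0.15 log units; within the scatter). Compound 4 is estimated at 1200 nM in this assay, with a range from 600 nM to 2400 nM.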

Compound 4, half-maximal inhibitory concentration: 1500 nM
Compound 4: middle estimate off by 1.3-fold (0.10 log units), on the low side, and the stated range covers the measured number.
By their numbers in this assay, from the lowest: compounds 1, 3, 4 and 2 (each within the scatter of the next).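

Isopropoxy in place of methyl on this aromatic carbon gives a 1.1-fold lower number from compound 2 to compound 4 (0.05 log units; within the scatter) in this assay, so a third alkoxy group, this one branched at the carbon bound to oxygen, also stays within the scatter of the methyl compound. The new steps also compare alkoxy groups directly: isopropyl in place of propyl on the oxygen gives a 1.4-fold higher number from compound 1 to compound 4 (0.13 log units; within the scatter), and isopropyl in place of isobutyl gives a 1.4-fold higher number from compound 3 to compound 4 (0.13 log units; within the scatter), so all of the exchanges among these three alkoxy groups and methyl tested so far leave the number within the scatter, and this position has not yet produced a step that can be read as a real difference. No measurement on hand gives any property of these compounds that could bear on these small steps.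

Going by these compounds, it remains open whether a group of another kind on this aromatic carbon, such as an amine, a carboxylic acid or a longer chain such as octyloxy, would move the number beyond the scatter. The compounds shown also leave open how changes elsewhere on the shared core, including the methyl on sulfur, would behave.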